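The compounds below may be only part of what the source reports. "The series", "measured", "known", "first", "only" and "open" are said of these compounds alone.

Measured in a functional assay on RPMI-8226 cells (Homo sapiens) for cytotoxicity, read by MTT assay, with a stated time of 48 h; a lower number here means a stronger inhibitor, a higher number a weaker inhibitor:
- Compound 1 `COC1(OC)C(Cl)=C(Cl)C(Cl)=C1Cl`: > 5000 nM, a limit
- Compound 2 `C#CC(C)(C)OC(=O)NN=C1C(Cl)=C(Cl)C(Cl)=C1Cl`: > 5000 nM, a limit

Compound 2 therefore has no exact position: its > 5000 nM is a limit and not a number. Neither measured compound gives a number, as the limit of > 5000 nM in this assay, at which 2 of the 2 values shown sit, shows.

Compound 3 `CC(=O)NN=C1C(Cl)=C(Cl)C(Cl)=C1Cl` has methyl in place of (1,1-dimethylprop-2-yn-1-yl)oxy on a carbonyl carbon. Among the measured compounds shown here, no measured step shows what such a change does. The expected change is a step that the limit leaves unreadable from compound 2 to compound 3, with no shift beyond the usual scatter in this assay. For compound 3, the estimated value is 6000 nM, with an expected range of 2500 nM to 15000 nM.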

Compound 3, half-maximal inhibitory concentration: 1000 nM
Compound 3: middle estimate off by 6.0-fold (0.78 log units), on the high side; the measured number lies below the stated range.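

On a carbonyl carbon, methyl in place of (1,1-dimethylprop-2-yn-1-yl)oxy gives an at least 5.0-fold lower number from compound 2 to compound 3 (0.69 log units; beyond the scatter) in this assay. Among the compounds shown here, this is the first sign that the group at this place matters for this read-out, and compound 3 is the only one of the three compounds with an exact number. The true size of the step stays unknown because compound 2 carries only a limit: the limit of > 5000 nM in this assay, at which 2 of the 3 values shown sit.

The swap changes the whole group at once, so it cannot say which part of the (1,1-dimethylprop-2-yn-1-yl)oxy group counts. On these data alone, whether an ethyl group, a longer chain or an amine at this place would lower the number further remains open.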